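Notes on the step from compound 2 to compound 3

A few compounds are considered here, and "the series" means these few. Any claim that something is new, unique, unknown or untested is made for them only; others in the source may bear on it.

Measured so far:
- compound 1 , `CNc1nc(C(F)(F)F)c(C(=O)N/N=C/c2cccc(C(F)(F)F)c2)s1`: in a functional assay on MCF7 cells (Homo sapiens) for inhibition, read by MTT assay, with a stated time of 72 h (on this read-out lower numbers stand for stronger inhibition and higher numbers for weaker inhibition), compound 1 reaches only the assay limit > 100 ug/mL.
- compound 2 , `CN(C(=O)NC(=O)c1ccc([N+](=O)[O-])cc1)c1nc(C(F)(F)F)c(C(=O)N/N=C/c2cccc(C(F)(F)F)c2)s1`: in this assay compound 2 gives 4.39 ug/mL.

For the measured compounds named here, compound 2 thus holds the only number in this set; the other entry is not a number but a limit, namely (the limit of > 100 ug/mL in this assay, at which 1 of the 2 values shown sits), where compound 1 sits. Going by the values given here, with one number and one limit, no step between measured compounds can be counted, so nothing measured shows what exchanging the aryl group on the acylurea carbonyl does.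

Compound 3 , `CN(C(=O)NC(=O)c1ccccc1F)c1nc(C(F)(F)F)c(C(=O)N/N=C/c2cccc(C(F)(F)F)c2)s1`, is the next point. It differs from compound 2 in one place: 2-fluorophenyl in place of 4-nitrophenyl on a carbonyl carbon. The rest of the molecule, including the acylurea on the shared core, is kept.

Among the compounds with values here, since no measured step covers this exchange, the expectation rests on compound 2 alone. A small loss is expected, about at the edge of the usual scatter, as a 2.1-fold higher number from compound 2 to compound 3 (0.31 log units; beyond the scatter). Compound 3 is therefore estimated at 9 ug/mL, in the range from 2.5 ug/mL to 35 ug/mL.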

Compound 3, half-maximal inhibitory concentration: 20.5 ug/mL
Beside the measured number, compound 3's estimate is 2.3-fold (0.36 log units) below it; the range from low to high includes it.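

In this assay, the aryl group on the acylurea carbonyl now has a measured effect: 2-fluorophenyl in place of 4-nitrophenyl on a carbonyl carbon gives a 4.7-fold higher number from compound 2 to compound 3 (0.67 log units; beyond the scatter), a modest step, and the 4-nitrophenyl group holds the lower number of the pair. The second aryl group also shows that a lower number than that of the core of compound 1 does not depend on the 4-nitrophenyl group alone, as ((2-fluorophenyl)carbonyl)carbamoyl in place of hydrogen on a nitrogen on an aromatic ring gives an at least 4.8-fold lower number from compound 1 to compound 3 (0.68 log units; beyond the scatter). That step sets a bound rather than a size, as its starting point is a limit and not a number: the limit of > 100 ug/mL in this assay, at which 1 of the 3 values shown sits.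

With the substituent and its ring position changing together, the step cannot yet be assigned to the loss of the nitro group, the arrival of the fluorine or the change of position. A plain phenyl, a 4-fluorophenyl or a 2-nitrophenyl group on this carbonyl would separate these readings, and a short alkyl chain in the same place would test whether an aromatic ring is needed there at all.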